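One Added Methyl, and a Series That Barely Moves

This account rests on a few compounds, and the source may have more. Where it says the series, first, only, none or still open, it means among the compounds named here.

In a functional assay on HeLa cells (Homo sapiens) for antiproliferative activity, read by MTT assay, with a stated time of 72 h (on this read-out higher numbers stand for weaker inhibition and lower numbers for stronger inhibition), compound 1 `COc1cc(C(=O)c2sc3ccccc3c2-c2ccc(C)cc2)cc(OC)c1OC` gives 3700 nM while compound 2 `COc1ccc(-c2c(C(=O)c3cc(OC)c(OC)c(OC)c3)sc3ccccc23)cc1` gives 4200 nM and compound 3 `COc1ccccc1-c1c(C(=O)c2cc(OC)c(OC)c(OC)c2)sc2ccccc12` gives 5000 nM so compound 1 stands level with both, within the usual scatter. Compound 4 `COc1ccc(-c2c(C(=O)c3cc(OC)c(OC)c(OC)c3)sc3ccccc23)cc1C` is still unmeasured and carries this change from compound 1: 4-methoxy-3-methylphenyl in place of 4-methylphenyl on an aromatic carbon with 4-methoxy-3-methylphenyl in place of 4-methylphenyl on an aromatic carbon. Among the measured compounds shown here, two measured steps bear on it: methoxy in place of methyl gave a 1.1-fold higher number from compound 1 to compound 2 (0.06 log units; within the scatter) and 2-methoxyphenyl in place of 4-methylphenyl gave a 1.4-fold higher number from compound 1 to compound 3 (0.13 log units; within the scatter) and so no step beyond the scatter is expected in this assay for this swap. For the measured compounds named here, no measured compound carries methoxy and methyl together on that ring. The expected step is a 1.1-fold higher number from compound 1 to compound 4 (0.03 log units; within the scatter) at most modestly. Compound 4 is expected at 4000 nM within a range of 1500 nM to 10000 nM in this estimate.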

Compound 4, half-maximal inhibitory concentration: 10000 nM
Compound 4: middle estimate off by 2.5-fold (0.40 log units), on the low side, and the stated range covers the measured number.
By their numbers in this assay, from the lowest: compounds 1, 2, 3 and 4 (each within the scatter of the next, the first and the last beyond it).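

Adding methyl to the 4-methoxyphenyl ring gives one of only two steps in this assay that clear the scatter, a 2.4-fold higher number from compound 2 to compound 4 (0.38 log units; beyond the scatter), and the other is the swap from 4-methylphenyl, a 2.7-fold higher number from compound 1 to compound 4 (0.43 log units; beyond the scatter). Against 2-methoxyphenyl the change stays within the scatter, a 2.0-fold higher number from compound 3 to compound 4 (0.30 log units; within the scatter). So at this position, where the earlier aryl swaps left the number level, methoxy and methyl together on the ring shift it modestly, though no evidence here explains that shift.

Going by these compounds, whether an ethyl group, a chlorine atom or an amine in place of that added methyl would shift the number as far remains open.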